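The source may report more compounds than this note shows. Statements on the series, on what has been measured and on what is new or still open speak of the compounds shown alone.

Measured so far in a functional assay on ileum (Cavia porcellus) for antagonist activity, with a stated time of 30 s; on this read-out higher numbers stand for weaker inhibition and lower numbers for stronger inhibition 
- compound 1 `O=C(O)c1cc(=O)c2ccc(OCCCOc3ccccc3)cc2o1` gives 1.4 ug/mL 
- compound 2 `O=C(O)c1cc(=O)c2ccc(OCCCCCOc3ccccc3)cc2o1` gives 0.4 ug/mL 

Compound 1 holds the higher of the two numbers, and so it is the weaker inhibitor of the pair. Among the measured compounds shown here, the only measured step is a 3.5-fold lower number from compound 1 to compound 2 (0.54 log units; beyond the scatter) and it is modest in size.

The unmeasured compound 3 `O=C(O)c1cc(=O)c2ccc(OCC(O)COc3ccccc3)cc2o1` differs from compound 1 at a single place (hydroxy in place of hydrogen on a saturated chain carbon bound to two saturated chain carbons), with hydroxy in place of hydrogen on a saturated chain carbon bound to two saturated chain carbons.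

The measured step puts 2-phenoxyethyl in place of phenoxy and adds no hydroxy. It therefore bears on this change only indirectly, as a yardstick for what one change to the chain can do in this assay here. For the measured compounds named here, no measured pair shows the effect of adding hydroxy, so neither direction is favoured and the range has to stay wide.

The estimated step is a 1.2-fold lower number from compound 1 to compound 3 (0.07 log units; within the scatter) and so no change beyond the scatter is expected. Compound 3 is estimated at 1.2 ug/mL (expected range 0.4 ug/mL to 4 ug/mL).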

Compound 3, half-maximal inhibitory concentration: 7 ug/mL
Beside the measured number, compound 3's estimate is 5.8-fold (0.77 log units) below it; measured number above the stated range.
By their numbers in this assay, from the lowest: compound 2; then compound 1; then compound 3.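

In this assay, hydroxy in place of hydrogen on a saturated chain carbon bound to two saturated chain carbons gives a 5.0-fold higher number from compound 1 to compound 3 (0.70 log units; beyond the scatter) and so moves the series toward weaker inhibition. Among the compounds shown here, this is the first measured sign that this chain carbon responds to a substituent, whereas the earlier step, a 3.5-fold lower number from compound 1 to compound 2 (0.54 log units; beyond the scatter) with 2-phenoxyethyl in place of phenoxy, went toward stronger inhibition and left this carbon unsubstituted. Nothing available accounts for the shift caused by the hydroxy.

Still open, from the compounds shown here alone, is whether the step belongs to the hydroxy in particular or would also follow from another group on the same saturated chain carbon, such as a methoxy or an amine. Also open, going by these compounds, is whether a hydroxy on the longer chain of compound 2 would produce a step of similar size and direction, and the two chain changes together therefore cannot yet be read as additive or otherwise.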